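Swapping the cyano group of compound 1 for hydrogen

The compounds below may be only part of what the source reports. "The series", "measured", "known", "first", "only" and "open" are said of these compounds alone.

Compound 1 `N#Cc1c(N)cccc1S(=O)(=O)c1ccccc1`: > 5000 nM
Compound 2 `COc1cccc(S(=O)(=O)c2cccc(N)c2C#N)c1`: > 200000 nM
Compound 3 `N#Cc1c(N)cccc1S(=O)(=O)c1cccc(Br)c1`: > 200000 nM

These three entries come from a functional assay on MT4 cells (Homo sapiens) for cytotoxicity (a higher number here means a weaker inhibitor, a lower number a stronger inhibitor), and each one is a limit, not a measured number. Compound 1 stands at a limit of > 5000 nM. Compound 2 and compound 3 share (the limit of > 200000 nM in this assay, at which 2 of the 3 values shown sit).

Compound 4 `Nc1cccc(S(=O)(=O)c2ccccc2)c1` is compound 1 with one change: hydrogen in place of cyano on an aromatic carbon. In words, hydrogen takes the place of cyano on an aromatic carbon. Among the compounds with values here, no measured step touches the cyano group. The nearest guides are a step that the two limits leave unreadable from compound 1 to compound 2 and a step that the two limits leave unreadable from compound 1 to compound 3, and neither has a size that can carry over, as is also true of a step that the two limits leave unreadable from compound 2 to compound 3. No direction can be read from them, so the expectation stays on the weak side of this assay, and compound 4 may well return only a limit. The expected change is a step that the limit leaves unreadable from compound 1 to compound 4. Compound 4 is estimated at 80000 nM, with an expected range from 10000 nM to 200000 nM.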

Compound 4, half-maximal inhibitory concentration: > 50000 nM
Compound 4: no number, only a limit (the forecaster's own chance of this, stated with the estimate: 80%); the middle value lies beyond the limit too.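

In this assay compound 4 gives > 50000 nM, which is a limit and not a number. Compound 1 also carries only a limit, and the step between compound 1 and compound 4 cannot be read. As far as these compounds go, whether the cyano group affects this read-out at all stays open: none of the four compounds has an exact value.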